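This account rests on a few compounds, and the source may have more. Where it says the series, first, only, none or still open, it means among the compounds named here.

Measured compounds:

Compound 1, `Cc1cccc(-n2cc(-c3ccccc3NS(=O)(=O)c3c[nH]c(=O)[nH]c3=O)nn2)c1`, in an ADME assay on L02 cells (Homo sapiens) for cytotoxicity, read by MTT assay, with a stated time of 24 h (on this read-out higher numbers stand for lower toxicity in this test and lower numbers for higher toxicity in this test), gives 21900 nM.
Compound 3, `Cc1cccc(-n2cc(-c3ccc(NS(=O)(=O)c4c[nH]c(=O)[nH]c4=O)cc3)nn2)c1`, in this assay gives 39000 nM.
Compound 2, `Cc1ccc(-n2cc(-c3ccccc3NS(=O)(=O)c3c[nH]c(=O)[nH]c3=O)nn2)cc1`, in this assay reaches only the limit (the limit of > 100000 nM in this assay, at which 1 of the 3 values shown sits), recorded as > 100000 nM.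

Three of the four compounds have been run. Compound 1 and compound 3 differ in their cores, and that difference between the two cores is not broken down here; their two values sit within the usual scatter of each other, so no order between them is claimed. The step from compound 1 to compound 2 is a single change, (4-methylphenyl in place of 3-methylphenyl on an aromatic nitrogen), and it produced an at least 4.5-fold higher number from compound 1 to compound 2 (0.65 log units; beyond the scatter), with the value of compound 2 given only as a limit.

Compound 4, `Cc1ccc(-n2cc(-c3ccc(NS(=O)(=O)c4c[nH]c(=O)[nH]c4=O)cc3)nn2)cc1`, has not yet been measured. Its relation to compound 3 is the same change, (4-methylphenyl in place of 3-methylphenyl on an aromatic nitrogen), made at the same place in the ring, only on the core of compound 3 rather than that of compound 1. Among the measured compounds shown here, compound 4 is expected to show a step of a 2.8-fold higher number from compound 3 to compound 4 (0.45 log units; beyond the scatter), since the earlier move from compound 1 to compound 2 gave an at least 4.5-fold higher number from compound 1 to compound 2 (0.65 log units; beyond the scatter) and nothing among the measured compounds points the other way. Compound 4 is therefore estimated to reach 110000 nM, with a range from 40000 nM to 300000 nM, and there is a fair chance that only a limit is reported.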

Compound 4, half-maximal cytotoxic concentration: "not toxic" (no number reported)
Compound 4 has no reported number here; no gap can be computed for the estimate.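

In this assay, among the compounds shown here, compound 4 is recorded as "not toxic" (no number reported), so no step from compound 3 to compound 4 can be read, and the two cannot be set side by side. The compounds shown leave open how large the effect of 4-methylphenyl in place of 3-methylphenyl is on either core, with compound 2 recorded only as a limit: the limit of > 100000 nM in this assay, at which 1 of the 4 values shown sits.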